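A few compounds are considered here, and "the series" means these few. Any claim that something is new, unique, unknown or untested is made for them only; others in the source may bear on it.

Compound 1 `Cc1cc(O)c(C2=NN(c3ccc(S(N)(=O)=O)cc3)C(c3ccccc3O)C2)cc1Cl` gives 67000 nM in a functional assay on SK-MEL-2 cells (Homo sapiens) for antiproliferative activity, with a stated time of 48 h; a higher number here means that more compound is tolerated, a lower number that less compound is tolerated.
Compound 2 `Cc1cc(O)c(C2=NN(c3ccc(S(N)(=O)=O)cc3)C(c3ccccc3Cl)C2)cc1Cl` gives 81100 nM in this assay.

Going by the values given here, only two numbers are at hand. Compound 2 and compound 1 lie within the scatter of each other, as the step of a 1.2-fold higher number from compound 1 to compound 2 (0.08 log units; within the scatter) shows, so nothing separates them. Compound 3 `Cc1cc(O)c(C2=NN(c3ccc(S(N)(=O)=O)cc3)C(/C=C/c3ccccc3)C2)cc1Cl` is not yet measured. It differs from compound 2 by 2-phenylethenyl in place of 2-chlorophenyl on a saturated ring carbon. Among the compounds with values here, the one measured step, a 1.2-fold higher number from compound 1 to compound 2 (0.08 log units; within the scatter), concerns the same position and swaps one substituent on the attached ring for another without moving the number beyond the scatter. Within the data shown here, no measured step replaces a whole aromatic ring with a 2-phenylethenyl group, so this change has no direct precedent here. Among the measured compounds shown here, the step from compound 2 to compound 3 is therefore expected to be a 1.0-fold lower number from compound 2 to compound 3 (0.01 log units; within the scatter), within the scatter, because the only comparison available, a 1.2-fold higher number from compound 1 to compound 2 (0.08 log units; within the scatter), was itself flat. For compound 3 the expected value is 80000 nM, within a range from 35000 nM to 180000 nM.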

Compound 3, concentration lethal to 50% of the cells: > 100000 nM
Compound 3 ended at the assay's limit (the forecaster's own chance of this, stated with the estimate: 10%); middle value at least 1.2-fold (0.09 log units) from the limit.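

In this assay compound 3 gives > 100000 nM, which is a limit of the assay and not a number: the limit of > 100000 nM in this assay, at which 1 of the 3 values shown sits.

The limit supports only floors, an at least 1.2-fold higher number from compound 2 to compound 3 (0.09 log units; that floor lies within the scatter) and an at least 1.4-fold higher number from compound 1 to compound 3 (0.17 log units; that floor lies within the scatter), so neither step is shown to go beyond the scatter, while the true size of each remains unknown. Going by these compounds alone, what the earlier compounds did not show is the outcome of replacing the whole aromatic ring on the saturated ring carbon, and with 2-phenylethenyl in that place, no step shows a lower number, meaning less compound tolerated.

The compounds shown leave open how far the true value of compound 3 lies past its limit, and whether the double bond outside the aromatic rings matters, a question that a 2-phenylethyl group on the same carbon would address. They also leave open whether a different kind of group at this position, such as an amine or a carboxylic acid, would bring the number down.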